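Replacing chloro with methoxy in compound 2

The source may hold more compounds than are shown below. What is called first, only, known or untested is meant among the compounds shown, and "the series" means these compounds.

Compound 1 `Clc1cc2nc(-c3cn(-c4ccccc4)nc3-c3ccccc3)[nH]c2cc1Cl`: 29700 nM
Compound 2 `Clc1ccc(-c2nn(-c3ccccc3)cc2-c2nc3cc(Cl)c(Cl)cc3[nH]2)cc1`: > 50000 nM (a limit)

In an ADME assay on HaCaT cells (Homo sapiens) for cytotoxicity, read by MTT assay, with a stated time of 48 h (a lower number here means a stronger inhibitor, a higher number a weaker inhibitor), compound 1 gives 29700 nM. Compound 2 has no number of its own, and its result is the limit of > 50000 nM in this assay, at which 1 of the 2 values shown sits.

Compound 3 `COc1ccc(-c2nn(-c3ccccc3)cc2-c2nc3cc(Cl)c(Cl)cc3[nH]2)cc1` differs from compound 2 by one change, methoxy in place of chloro on an aromatic carbon, para to a large group: methoxy in place of chloro on an aromatic carbon.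

Within the data shown here, only one measured step bears on this change, and it is an at least 1.6-fold higher number from compound 1 to compound 2 (0.22 log units; that floor lies within the scatter). Among the measured compounds shown here, that step put chloro in place of hydrogen on an aromatic carbon, and no measured compound carries methoxy. It therefore gives only weak guidance, and its floor does not clear the scatter. No step beyond the scatter is expected in this assay, in either direction. The expected step is an at least 1.2-fold lower number from compound 2 to compound 3 (0.09 log units; that floor lies within the scatter), and it can be counted only from a limit. For compound 3 the estimate is 40000 nM, with an expected range from 15000 nM to 100000 nM.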

Compound 3, half-maximal inhibitory concentration: > 50000 nM
Compound 3: a limit, no number; the forecaster's own chance of this, stated with the estimate: 45%; middle value at least 1.2-fold (0.09 log units) from the limit.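

In this assay, compound 3 gives only a limit, > 50000 nM, and no number of its own. The one readable new result is an at least 1.6-fold higher number from compound 1 to compound 3 (0.22 log units; that floor lies within the scatter), so methoxy, like chloro, gives a floor at this position rather than a measured size, while the steps between the two limits cannot be read. What compound 3 adds is that a second, different group at this position, with an oxygen and a hydrogen-bond acceptor where chloro has neither, also ends at the same limit, so the reading no longer rests on chloro alone: the limit of > 50000 nM in this assay, at which 2 of the 3 values shown sit.

As far as these compounds go, whether 4-chlorophenyl and 4-methoxyphenyl differ at all in this assay stays open, as does whether either truly lies beyond the scatter from the unsubstituted phenyl of compound 1. An amine or a carboxylic acid at this position could show whether any group here gives a number that can be read against compound 1.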